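Swapping the amide's aryl group in compound 3 for compound 4

This account rests on a few compounds, and the source may have more. Where it says the series, first, only, none or still open, it means among the compounds named here.

Compound 3 `CN1CCN(c2ccc(Nc3nc(-c4cccc(NC(=O)c5ccc(C(C)(C)C)cc5)c4)sc3C(N)=O)cc2)CC1` has a primary amide on its shared core, and in a functional assay on Raji cells (Homo sapiens) for antiproliferative activity, read by CCK-8 assay, with a stated time of 72 h, tested at 40 uM (a higher number here means more inhibition at the concentration tested (going by the name of the read-out), a lower number less inhibition), compound 3 gives 12.1%. That places compound 3 second highest of the three numbers shown: compound 1 `CCOC(=O)c1sc(-c2cccc(NC(=O)c3ccc(C(C)(C)C)cc3)c2)nc1Nc1ccc(N2CCN(C)CC2)cc1` gives 4.22%, and the move a number 7.9 percentage points higher from compound 1 to compound 3 (within the scatter) stays within the scatter, while compound 2 `CN1CCN(c2ccc(Nc3nc(-c4cccc(NC(=O)c5ccc(Cl)cc5)c4)sc3C(=O)O)cc2)CC1` gives 90.9%, far beyond it. Compound 4 `CN1CCN(c2ccc(Nc3nc(-c4cccc(NC(=O)c5ccc(C(F)(F)F)cn5)c4)sc3C(N)=O)cc2)CC1` differs from compound 3 by 5-(trifluoromethyl)pyridin-2-yl in place of 4-(tert-butyl)phenyl on a carbonyl carbon. Within the data shown here, no measured step alters this aryl group alone; compound 2 differs from compound 3 in two places, so its high number cannot be assigned to either change. The expected step of a number 12.9 percentage points higher from compound 3 to compound 4 (beyond the scatter) is therefore uncertain, and compound 4 is estimated at 25%, within 5% to 60%.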

Compound 4, a percentage reported as inhibition, at one concentration (the size of the read-out at that concentration, not a potency): 84.6%
Compound 4: middle estimate off by 59.6 percentage points, on the low side; the whole stated range lies below it.
By their numbers in this assay, from the lowest: compounds 1 and 3 (each within the scatter of the next); then compounds 4 and 2 (each within the scatter of the next).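

In this assay, the group on the amide carbonyl proves decisive: with the primary amide on the core unchanged, 5-(trifluoromethyl)pyridin-2-yl in place of 4-(tert-butyl)phenyl gives a number 72.5 percentage points higher from compound 3 to compound 4 (beyond the scatter). This is the first single change shown to move the number beyond the scatter, unlike a number 7.9 percentage points higher from compound 1 to compound 3 (within the scatter). Nothing at hand explains why this swap has so large an effect. From the compounds shown here alone, the swap changes the ring nitrogen and the trifluoromethyl group at once, and which of them carries the step stays open. A 4-(trifluoromethyl)phenyl group on the same carbonyl would separate the two.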